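Swapping thiophen-3-yl for phenyl on a shared core

This account rests on a few compounds, and the source may have more. Where it says the series, first, only, none or still open, it means among the compounds named here.

- compound 1 `Oc1cccc(-c2cc(-c3cccc(Cl)c3)cc(-c3ccco3)n2)c1` gives 680 nM
- compound 2 `Oc1cccc(-c2cc(-c3cccc(Cl)c3)cc(-c3ccsc3)n2)c1` gives 680 nM

Going by the values given here, in a functional assay on T47D cells (Homo sapiens) for cytotoxicity, read by CCK-8 assay and cell counting, with stated times of 4 h and 2 days (on this read-out lower numbers stand for stronger inhibition and higher numbers for weaker inhibition), compound 2 gives 680 nM and stands level with compound 1, the only other compound measured so far. The next compound is compound 3 `Oc1cccc(-c2cc(-c3cccc(Cl)c3)cc(-c3ccccc3)n2)c1` with phenyl in place of thiophen-3-yl on an aromatic carbon, next to the ring nitrogen phenyl in place of thiophen-3-yl on an aromatic carbon and otherwise the same shared core. Among the compounds with values here, one measured step bears on this change, the exchange of furan-2-yl for thiophen-3-yl at that carbon, no change at the digits printed from compound 1 to compound 2 (within the scatter) and so within the scatter. Within the data shown here, that step joins two five-membered rings, and no measured compound yet carries a six-membered aromatic ring of carbon only there, so the evidence is thin. The expected step of a 1.0-fold lower number from compound 2 to compound 3 (0.02 log units; within the scatter) in this assay is no larger than the scatter, with no direction favoured. Compound 3 is estimated at about 650 nM with an expected range from 250 nM to 1700 nM in this measurement.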

Compound 3, half-maximal inhibitory concentration: 680 nM
For compound 3 the middle estimate is 1.0-fold (0.02 log units) below the measured one; low and high end bracket the measured number.
By their numbers in this assay, from the lowest: compounds 1, 2 and 3 (each within the scatter of the next).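

Phenyl on this carbon, next to the ring nitrogen, gives no change at the digits printed from compound 2 to compound 3 (within the scatter) in this assay, and the comparison with furan-2-yl gives no change at the digits printed from compound 1 to compound 3 (within the scatter). Going by these compounds alone, the earlier pair had compared only two five-membered rings, whereas these steps show that a six-membered aromatic ring of carbon only, with no hetero atom and no hydrogen-bond acceptor, reads the same across these three compounds. Nothing on hand explains why the three aromatic rings read alike.

The compounds shown leave open whether this level holds for anything other than an unsubstituted aromatic ring at this carbon, such as an amine, a carboxylic acid, a longer alkyl chain or a phenyl carrying a methoxy group. They also leave open how much the 3-chlorophenyl and 3-hydroxyphenyl groups, shared by all three compounds, contribute to the reading.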